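Isopropoxy for cyclohexylmethyl on the amide carbonyl

This account rests on a few compounds, and the source may have more. Where it says the series, first, only, none or still open, it means among the compounds named here.

Measured compounds:
- compound 1 `O=C(CCCC1CCN(C(=O)CC2CCCCC2)CC1)c1ncco1`: 100 nM
- compound 2 `O=C(CCCC1CCN(S(=O)(=O)CCc2ccccc2)CC1)c1ncco1`: 6 nM
- compound 3 `CC(C)(C)CC(=O)N1CCC(CCCC(=O)c2ncco2)CC1`: 90 nM

In an assay on isolated protein for inhibition of Fatty-acid amide hydrolase 1 (Homo sapiens) (on this read-out lower numbers stand for stronger inhibition and higher numbers for weaker inhibition), compound 1 gives 100 nM, the highest of the three numbers. Compound 3 lies nearest, and the step of a 1.1-fold lower number from compound 1 to compound 3 (0.05 log units; within the scatter) is within the scatter. Compound 2 lies furthest, giving 6 nM, a value well beyond the scatter from that of compound 1.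

The unmeasured compound 4 `CC(C)OC(=O)N1CCC(CCCC(=O)c2ncco2)CC1` differs from compound 1 in one place: isopropoxy in place of cyclohexylmethyl on a carbonyl carbon. Among the compounds with values here, only one measured step bears on this position, the step of a 1.1-fold lower number from compound 1 to compound 3 (0.05 log units; within the scatter), in which a change at the saturated chain carbon bound to the carbonyl left the number essentially unchanged. That step does not involve an oxygen bound to the carbonyl, so it gives only weak guidance. Within the data shown here, no measured pair shows an oxygen entering at this carbonyl.

On this evidence compound 4 is expected to stay close to compound 1, with a step of a 1.5-fold higher number from compound 1 to compound 4 (0.18 log units; within the scatter) that may lean slightly toward a higher number but is not expected to pass clearly beyond the scatter. The estimate for compound 4 in this assay is 150 nM, with a range from 40 nM to 600 nM.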

Compound 4, half-maximal inhibitory concentration: 4 nM
Compound 4: the middle estimate sits 38-fold (1.57 log units) above what was measured; the measured number lies below the stated range.
By their numbers in this assay, from the lowest: compounds 4 and 2 (each within the scatter of the next); then compounds 3 and 1 (each within the scatter of the next).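

In this assay, the substituent on a carbonyl carbon whose other neighbours are amide-type nitrogen in a ring proves far from indifferent: isopropoxy in place of cyclohexylmethyl gives a 25-fold lower number from compound 1 to compound 4 (1.40 log units; beyond the scatter), and isopropoxy in place of neopentyl gives a 23-fold lower number from compound 3 to compound 4 (1.35 log units; beyond the scatter). The earlier step, a 1.1-fold lower number from compound 1 to compound 3 (0.05 log units; within the scatter), exchanged one carbon-only group for another and stayed within the scatter, so the flat response seen there does not extend to a group that places an oxygen on this carbonyl carbon. Nothing in the available data accounts for the size of this change.

Because each new step changes several features at once, the compounds shown cannot tell whether the oxygen on the carbonyl carbon, the smaller group or the loss of the ring carries the shift. A cyclohexyloxy group at this place would keep the ring together with the oxygen, and an isopropylamino group would keep the isopropyl part with a nitrogen in place of the oxygen, so that each feature could be read on its own.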